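Chloro in Place of Methoxy on the Shared Core

The source may hold more compounds than are shown below. What is called first, only, known or untested is meant among the compounds shown, and "the series" means these compounds.

Of the compounds shown here, three on a shared core have been measured in a functional assay on Hs-578T cells (Homo sapiens) for inhibition, read by sulforhodamine B assay, with a stated time of 48 h, tested at 10 uM; on this read-out higher numbers stand for more inhibition at the one concentration tested (going by the name of the read-out) and lower numbers for less inhibition. Compound 1 `Brc1cn2ccnc2c(-c2ccc3ncn(C4CCCCC4)c3c2)n1` carries a bromo group and gives 16.1%. Compound 2 `COc1ccc(-c2cn3ccnc3c(-c3ccc4ncn(C5CCCCC5)c4c3)n2)cc1` carries a 4-methoxyphenyl group and gives 80%. Compound 3 `CC(=O)c1ccc(-c2cn3ccnc3c(-c3ccc4ncn(C5CCCCC5)c4c3)n2)cc1` carries a 4-acetylphenyl group and gives 6.34%. Compound 2 therefore holds the highest number of the three, and both a number 63.9 percentage points higher from compound 1 to compound 2 (beyond the scatter) and a number 73.7 percentage points lower from compound 2 to compound 3 (beyond the scatter) lie beyond the scatter. Compound 4 `Clc1ccc(-c2cn3ccnc3c(-c3ccc4ncn(C5CCCCC5)c4c3)n2)cc1` has not yet been measured; it differs from compound 2 by chloro in place of methoxy on an aromatic carbon.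

Among the measured compounds shown here, two measured steps touch compound 2. The step from compound 1 to compound 2 shows that 4-methoxyphenyl in place of bromo raised the read-out strongly, and the step from compound 2 to compound 3 shows that acetyl in place of methoxy lowered it strongly. For the measured compounds named here, neither step involves a chloro group, so no measured pair tells directly what chloro in place of methoxy does. Going by the values given here, because a number 73.7 percentage points lower from compound 2 to compound 3 (beyond the scatter) was large for the one exchange of the methoxy that has been measured, a drop from compound 2 is expected, though its size is uncertain. Compound 4 is therefore expected to give about 45%, within 10% to 80%, which corresponds to an expected step of a number 35 percentage points lower from compound 2 to compound 4 (beyond the scatter).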

Compound 4, a percentage reported as inhibition, at one concentration (the size of the read-out at that concentration, not a potency): 6.35%
Estimate against measurement, compound 4: 38.7 percentage points above; measured number below the stated range.
By their numbers in this assay, from the lowest: compounds 3, 4 and 1 (each within the scatter of the next); then compound 2.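

In this assay, chloro in place of methoxy gave a number 73.7 percentage points lower from compound 2 to compound 4 (beyond the scatter), a step of the same printed size as a number 73.7 percentage points lower from compound 2 to compound 3 (beyond the scatter), so two different replacements of the methoxy on this six-membered aromatic ring have now each removed nearly all of the read-out. Chloro and acetyl cannot be told apart at this position, with a number 0 percentage points higher from compound 3 to compound 4 (within the scatter), and the 4-chlorophenyl compound also stays within the scatter of the bromo compound, with a number 9.8 percentage points lower from compound 1 to compound 4 (within the scatter), so an added phenyl ring does not by itself go with a high read-out, and among these four compounds only the 4-methoxyphenyl group stands apart. No measured evidence is available that would explain this sharp dependence on the group at this position.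

The compounds shown leave open whether the high read-out belongs to methoxy alone or extends to related groups on the same aromatic carbon, such as hydroxy, ethoxy or an amine. Among the compounds shown here, they also leave open how compound 2 would behave across a range of concentrations, as its single reading of 80% is not a potency.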